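Aryl substituent exchange on the shared core: compound 4

A few compounds are considered here, and "the series" means these few. Any claim that something is new, unique, unknown or untested is made for them only; others in the source may bear on it.

compound 1 `CCCCc1ccc(-c2cc(N3CCC(CCNS(N)(=O)=O)CC3)ncn2)cc1` — 13300 nM in a functional assay on HT-29 cells (Homo sapiens) for antiproliferative activity, read by sulforhodamine B assay, with a stated time of 48 h; on this read-out higher numbers stand for weaker inhibition of growth and lower numbers for stronger inhibition of growth
compound 2 `COc1ccc(-c2cc(N3CCC(CCNS(N)(=O)=O)CC3)ncn2)cc1` — 72300 nM in this assay
compound 3 `NS(=O)(=O)NCCC1CCN(c2cc(-c3ccc(C(F)(F)F)cc3)ncn2)CC1` — 22600 nM in this assay

Compound 3 stands second highest of the three numbers in this assay. Its nearest neighbour is compound 1, reached by a 1.7-fold higher number from compound 1 to compound 3 (0.23 log units; within the scatter), which sits within the scatter, while compound 2 lies further off, the step of a 3.2-fold lower number from compound 2 to compound 3 (0.51 log units; beyond the scatter) being beyond the scatter. The only part that varies across these three compounds is the substituent on the aromatic ring, so the measured steps describe how that single position tolerates exchange.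

Compound 4 `COC(=O)c1ccc(-c2cc(N3CCC(CCNS(N)(=O)=O)CC3)ncn2)cc1` continues the same kind of exchange: methoxycarbonyl in place of trifluoromethyl on an aromatic carbon. For the measured compounds named here, no measured step puts a methoxycarbonyl at this position, so the expectation rests on the size of the steps already seen there: a 5.4-fold higher number from compound 1 to compound 2 (0.74 log units; beyond the scatter), a 3.2-fold lower number from compound 2 to compound 3 (0.51 log units; beyond the scatter) and a 1.7-fold higher number from compound 1 to compound 3 (0.23 log units; within the scatter), each modest or within the scatter. The exchange of trifluoromethyl for methoxycarbonyl is therefore expected to move the number in this assay only a little, with at most a modest shift and no clear direction. Compound 4 is estimated at 30000 nM, with a range from 10000 nM to 90000 nM, so that a 1.3-fold higher number from compound 3 to compound 4 (0.12 log units; within the scatter) is expected to fall within the scatter.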

Compound 4, concentration for 50% growth inhibition: 19600 nM
For compound 4 the middle estimate is 1.5-fold (0.18 log units) above the measured one; the measured number falls inside the stated range.
By their numbers in this assay, from the lowest: compounds 1, 4 and 3 (each within the scatter of the next); then compound 2.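

In this assay, for the compounds shown here, methoxycarbonyl on the aromatic carbon para to a large group brings hydrogen-bond acceptors and a double bond outside aromatic rings that trifluoromethyl does not have, yet the exchange for trifluoromethyl stays within the scatter (a 1.2-fold lower number from compound 3 to compound 4 (0.06 log units; within the scatter)), as does the exchange for butyl (a 1.5-fold higher number from compound 1 to compound 4 (0.17 log units; within the scatter)), so this position now holds three differently built groups with no step among them beyond the scatter. Going by these compounds alone, the exchange of methoxy for methoxycarbonyl does go beyond the scatter, though only modestly (a 3.7-fold lower number from compound 2 to compound 4 (0.57 log units; beyond the scatter)), and this leaves methoxy as the only one of the four groups separated from all the others. No data at hand account for this separation, which sets methoxy apart from methoxycarbonyl even though both groups carry oxygen.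

Still open, as far as these compounds go, is whether any group at this position can bring the number clearly below the level shared by butyl, trifluoromethyl and methoxycarbonyl. An amine, a carboxylic acid or a longer chain would test this, and the compounds shown do not say whether the separation of methoxy extends to other groups.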